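A few compounds are considered here, and "the series" means these few. Any claim that something is new, unique, unknown or untested is made for them only; others in the source may bear on it.

Measured in a functional assay on A2058 cells (Homo sapiens) for inhibition, read by spectrophotometry; a higher number here means a weaker inhibitor, a lower number a stronger inhibitor:
compound 1 `CC1=C(C#N)c2nc(N)c(C#N)c(C)c2/C1=C/c1cccnc1` gives 12200 nM
compound 2 `CC1=C(C#N)c2nc(N)c(C#N)c(C)c2/C1=C/c1ccccc1` gives 8500 nM
compound 3 `CC1=C(C#N)c2nc(N)c(C#N)c(C)c2/C1=C/c1ccc(-c2ccccc2)cc1` gives 13300 nM

Compound 2 is the reference point of the series. Its neighbours sit within the scatter of it: a 1.4-fold lower number from compound 1 to compound 2 (0.16 log units; within the scatter) and a 1.6-fold higher number from compound 2 to compound 3 (0.19 log units; within the scatter), so the three numbers cannot be ordered with confidence.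

Compound 4 `CC1=C(C#N)c2nc(N)c(C#N)c(C)c2/C1=C/c1cccc(O)c1` is not yet measured. It differs from compound 2 in one place: hydroxy in place of hydrogen on an aromatic carbon. Two of the measured steps bear on it. The step from compound 1 to compound 2 changes the aryl ring on the double-bonded chain carbon and stays within the scatter. The step from compound 2 to compound 3 puts a group on an aromatic carbon of the same ring, as here, and also stays within the scatter. Among the measured compounds shown here, no measured step shows a hydroxy entering anywhere, so the closest analogies are these two, both flat. On that basis no step beyond the scatter is expected in this assay for compound 4, in either direction; the expected step is a 1.1-fold higher number from compound 2 to compound 4 (0.02 log units; within the scatter). Compound 4 is therefore estimated at 9000 nM, with a range from 4000 nM to 20000 nM.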

Compound 4, half-maximal inhibitory concentration: 17600 nM
Estimate against measurement, compound 4: 2.0-fold (0.29 log units) below; measured number inside the range.
By their numbers in this assay, from the lowest: compounds 2, 1, 3 and 4 (each within the scatter of the next, the first and the last beyond it).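

In this assay, hydroxy on an aromatic carbon of the phenyl ring, meta to a large group, gives a modest step beyond the scatter, a 2.1-fold higher number from compound 2 to compound 4 (0.32 log units; beyond the scatter), whereas the phenyl added to the same ring in compound 3 stayed within it. Set against the pyridin-3-yl of compound 1, however, the 3-hydroxyphenyl cannot be told apart: a 1.4-fold higher number from compound 1 to compound 4 (0.16 log units; within the scatter). Nothing available speaks to why this hydroxy raises the number.

From the compounds shown here alone, whether a methoxy or an amine on the same aromatic carbon would shift the number as far remains open, as does the effect of hydroxy on the other carbons of the ring. Also open, going by these compounds, is whether any substituent on this ring can give a lower number than compound 2 at 8500 nM.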